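Moving the Methyl Group: From Compound 3 to Compound 4

The source may report more compounds than this note shows. Statements on the series, on what has been measured and on what is new or still open speak of the compounds shown alone.

Of the compounds shown here, three sharing one core have been tested in an assay on CHO cells for displacement of a labelled ligand from prostaglandin E2 receptor EP3 subtype (Mus musculus), read by scintillation counting, with a stated time of 60 min; a higher number here means a weaker inhibitor, a lower number a stronger inhibitor. Compound 1 `O=C(O)c1csc(SCCN2C(=O)CC[C@@H]2/C=C/[C@@H](O)Cc2cccc(-c3ccccc3)c2)n1` carries a plain phenyl group and gives 4300 nM. Compound 2 `O=C(O)c1csc(SCCN2C(=O)CC[C@@H]2/C=C/[C@@H](O)Cc2cccc(-c3ccc(Cl)cc3)c2)n1` has a chloro in place of hydrogen on an aromatic carbon, and in this assay compound 2 gives only the limit > 10000 nM. Compound 3 `Cc1ccc2oc(-c3cccc(C[C@H](O)/C=C/[C@H]4CCC(=O)N4CCSc4nc(C(=O)O)cs4)c3)nc2c1` has a 5-methyl-1,3-benzoxazol-2-yl in place of phenyl, and in this assay compound 3 likewise gives only the limit > 10000 nM. Both measured steps point the same way: an at least 2.3-fold higher number from compound 1 to compound 2 (0.36 log units; beyond the scatter) and an at least 2.3-fold higher number from compound 1 to compound 3 (0.36 log units; beyond the scatter). Between the two limits, a step that the two limits leave unreadable from compound 2 to compound 3. Compound 3 therefore stands at the limit of > 10000 nM in this assay, at which 2 of the 3 values shown sit, and its true value could lie anywhere beyond that point.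

Compound 4 `Cc1cccc2oc(-c3cccc(C[C@H](O)/C=C/[C@H]4CCC(=O)N4CCSc4nc(C(=O)O)cs4)c3)nc12` differs from compound 3 only in where the methyl sits: 4-methyl-1,3-benzoxazol-2-yl in place of 5-methyl-1,3-benzoxazol-2-yl on an aromatic carbon. Within the data shown here, no measured step moves a methyl within this group, so none of the steps gives a direct guide; the nearest information is simply that compound 3 itself sits at the limit. The expected step is a step that the limit leaves unreadable from compound 3 to compound 4, within the scatter. For compound 4 the estimate is 15000 nM, with a range from 5000 nM to 50000 nM, and the result is expected most likely to be reported again only as a limit.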

Compound 4, inhibition constant: > 10000 nM
Compound 4: no number, only a limit (the forecaster's own chance of this, stated with the estimate: 70%); the middle value does not contradict the limit.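

Placing the methyl as in the 4-methyl-1,3-benzoxazol-2-yl group, rather than the 5-methyl-1,3-benzoxazol-2-yl group, does not bring the compound back into the range where this assay returns a number, so neither methyl placement shown here gives a measurable value, and the set now gathers at one end of the assay: the limit of > 10000 nM in this assay, at which 3 of the 4 values shown sit. Against the plain phenyl group, the new group gives an at least 2.3-fold higher number from compound 1 to compound 4 (0.36 log units; beyond the scatter), so the loss seen with compound 3 is not confined to one methyl placement. The steps linking compound 2, compound 3 and compound 4 to one another cannot be read, as each joins two limits, and no order among these three compounds can be stated.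

On these data alone, how far beyond the limit compound 3 and compound 4 really lie stays open, and so does whether moving the methyl changes binding at all. Also open, as far as these compounds go, is whether an unsubstituted 1,3-benzoxazol-2-yl group or a pyridine ring in place of the phenyl group would stay closer to compound 1 or also fall to the limit.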